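Shortening the chain and returning to a thiourea end group

The source may report more compounds than this note shows. Statements on the series, on what has been measured and on what is new or still open speak of the compounds shown alone.

Compound 3 `C/N=C(/NC#N)NCCCCCn1nc(-c2ccccc2)ccc1=O` gives 47.6% in a functional assay on the whole organism with Rattus norvegicus as the target, at a dose of 100 mg/kg (a higher number here means more inhibition at the dose given (going by the name of the read-out), a lower number less inhibition), the lowest of the three numbers: compound 2 `CC/N=C(/NC#N)NCCCCn1nc(-c2ccccc2)ccc1=O` gives 58.8% and compound 1 `CC/N=C(\S)NCCCCCn1nc(-c2ccccc2)ccc1=O` gives 66.4%, both beyond the scatter above it. Compound 4 `N/C(S)=N/CCCCn1nc(-c2ccccc2)ccc1=O` differs from compound 3 by a group of 4 heavy atoms (1 carbon, 2 nitrogen, 1 sulfur; no ring) in place of a group of 8 heavy atoms (4 carbon, 4 nitrogen; no ring), on a saturated chain carbon, four bonds along the chain from an aromatic nitrogen. The step of a number 7.6 percentage points lower from compound 1 to compound 2 (within the scatter) bears on this, since it exchanges a sulfur-bearing group for a nitrile-bearing one at the same place and lies within the scatter; the step of a number 11.2 percentage points lower from compound 2 to compound 3 (beyond the scatter) also touches that place. Reversing those two steps suggests a modest rise in this assay, though no measured pair isolates the present change. Compound 4 is therefore expected at 58% (range 42% to 74%), an estimated step of a number 10.4 percentage points higher from compound 3 to compound 4 (beyond the scatter).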

Compound 4, a percentage reported as inhibition, in the whole organism at one dose (the size of the read-out at that dose, not a potency): 72%
Compound 4: middle estimate off by 14 percentage points, on the low side; measured number inside the range.
By their numbers in this assay, from the lowest: compound 3; then compounds 2, 1 and 4 (each within the scatter of the next, the first and the last beyond it).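

In this assay, the sulfur-bearing group of 4 heavy atoms in place of the nitrile-bearing group of 8 heavy atoms gives a number 24.4 percentage points higher from compound 3 to compound 4 (beyond the scatter) and a number 13.2 percentage points higher from compound 2 to compound 4 (beyond the scatter) as the two steps at this place on the saturated chain carbon. Against the larger sulfur-bearing group, the change gives a number 5.6 percentage points higher from compound 1 to compound 4 (within the scatter) so the sulfur-bearing end group keeps its level with fewer heavy atoms here.

Going by these compounds, whether a urea, with oxygen in place of the sulfur, holds this level remains open, as does a longer chain carrying the same small group. No supporting evidence accounts for these differences.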